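A few compounds are considered here, and "the series" means these few. Any claim that something is new, unique, unknown or untested is made for them only; others in the source may bear on it.

Measured so far in a physicochemical assay for lipophilicity, read by HPLC, measured as chromatographic lipophilicity, at pH 7.4; a higher number here means a more lipophilic compound, a lower number a more polar compound:
compound 1 `O=C(C1CCOC1)N1N=CCC1c1ccccc1` gives 3
compound 2 `O=C(c1cccnc1)N1CCC(C(=O)N2N=CCC2c2ccccc2)CC1` gives 2.6
compound 3 `N#Cc1cnc(N2CCC(C(=O)N3N=CC[C@H]3c3cc(F)cc(F)c3)CC2)cn1` gives 5.2

Of these three, compound 1 stands second highest, with compound 2 lower and compound 3 much higher, both gaps beyond the scatter. Still unmeasured is compound 4 `O=C(C1CCC1)N1N=CCC1c1ccccc1`, which carries cyclobutyl in place of oxolan-3-yl on a carbonyl carbon. For the measured compounds named here, no measured pair shows this change, so the expectation rests on the structural change alone: a rise in this assay beyond the scatter. The expected upward step is estimated as a number 0.80 log units higher from compound 1 to compound 4 (beyond the scatter) in size. For compound 4 the estimated value is 3.8 (expected range 3.4 to 4.3).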

Compound 4, distribution coefficient: 4.7
For compound 4 the middle estimate is 0.90 log units below the measured one; measured number outside the range, above it.
By their numbers in this assay, from the lowest: compound 2; then compound 1; then compound 4; then compound 3.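

In this assay, the pair gives the series its first comparison differing in one place: cyclobutyl in place of oxolan-3-yl on a carbonyl carbon is a large step, a number 1.70 log units higher from compound 1 to compound 4 (beyond the scatter), so the read-out is sensitive to the group at this position. The change removes the ring oxygen and alters the ring size together, and this pair cannot separate the two. No measured evidence bears on the origin of the step.

Open, as far as these compounds go, is whether cyclopentyl, a five-membered ring of carbon only, would read closer to compound 1 or compound 4. Also open, from the compounds shown here alone, is how an amine or a longer chain would read at this position.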